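Sigma-1 series: homologation of the N-arylalkyl chain

A few compounds are considered here, and "the series" means these few. Any claim that something is new, unique, unknown or untested is made for them only; others in the source may bear on it.

Measured compounds:
compound 1 `COC1Cc2sccc2C2(CCN(CCC(C)C)CC2)O1` — 1 nM
compound 2 `COC1Cc2sccc2C2(CCNCC2)O1` — 602 nM
compound 3 `COC1Cc2sccc2C2(CCN(CCCc3ccccc3)CC2)O1` — 2.4 nM

In an assay on membranes from brain for displacement of a labelled ligand from Sigma non-opioid intracellular receptor 1 (Cavia porcellus) (a higher number here means a weaker inhibitor, a lower number a stronger inhibitor), compound 3 stands second of the three numbers. Compound 1 sits nearest, the step being a 2.4-fold higher number from compound 1 to compound 3 (0.38 log units; beyond the scatter). Compound 2 sits furthest away; its value of 602 nM against compound 3 at 2.4 nM shows a wide gap, with no single-point comparison between the two.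

Compound 4 `COC1Cc2sccc2C2(CCN(CCCCc3ccccc3)CC2)O1` is not yet measured in this assay. It differs from compound 3 by benzyl in place of phenyl on a saturated chain carbon, three bonds along the chain from an amine nitrogen in a ring.

Neither measured step is a direct homologation of the chain. The step of a 600-fold higher number from compound 1 to compound 2 (2.78 log units; beyond the scatter) shows only that stripping the nitrogen substituent altogether costs a great deal. The step of a 2.4-fold higher number from compound 1 to compound 3 (0.38 log units; beyond the scatter) shows that swapping the chain terminus between a branched alkyl and an aromatic group moves the number only modestly. Lengthening the chain by one carbon while keeping the aromatic terminus is a smaller change than either, so the expected step of a 1.2-fold lower number from compound 3 to compound 4 (0.08 log units; within the scatter) is small and could fall within the scatter in either direction.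

The estimate for compound 4 in this assay is 2 nM, with a range from 0.7 nM to 6 nM.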

Compound 4, inhibition constant: 7.7 nM
Estimate against measurement, compound 4: 3.9-fold (0.59 log units) below, and the stated range ends below it.
By their numbers in this assay, from the lowest: compound 1; then compound 3; then compound 4; then compound 2.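

In this assay, among these compounds, the added carbon in the aromatic-ended chain gives a 3.2-fold higher number from compound 3 to compound 4 (0.51 log units; beyond the scatter), so this position is not indifferent to chain length, a point that the earlier steps, which changed the chain in other ways, could not settle. With the branched chain of compound 1 as reference, the change to the longer aromatic chain amounts to a 7.7-fold higher number from compound 1 to compound 4 (0.89 log units; beyond the scatter), which exceeds a 2.4-fold higher number from compound 1 to compound 3 (0.38 log units; beyond the scatter) yet remains much smaller than the loss on removing the chain altogether, a 600-fold higher number from compound 1 to compound 2 (2.78 log units; beyond the scatter), so compound 4 keeps most of what the nitrogen substituent contributes. No data are available that bear on the origin of the step from the three-carbon to the four-carbon aromatic chain.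

A single added carbon gives one step only, so the compounds shown cannot tell whether the number keeps rising with a longer chain such as phenylpentyl or has a lowest point at a shorter chain such as phenethyl. They also leave open whether the same step holds when the phenyl terminus is replaced by a pyridine ring or when a hydroxyl group is placed on the chain.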